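Amide in place of hydroxymethyl on the shared core

This account rests on a few compounds, and the source may have more. Where it says the series, first, only, none or still open, it means among the compounds named here.

Within the data shown here, compound 2 `CCCCCCCCCCCCN(C)C(=O)Cn1cc(Cc2cnc(=O)n(CCO)c2)c(=O)nc1SCc1ccc(F)cc1` stands highest of the two numbers measured so far: in a functional assay on a cell-free system (plasma) for inhibition of platelet-activating factor acetylhydrolase (Homo sapiens), tested at 100 nM (a lower number here means less inhibition, a higher number more inhibition at the concentration tested (going by the name of the read-out)), compound 2 gives 77%. Among the measured compounds shown here, compound 1 `CCCCCCCCCCCCN(C)C(=O)Cn1cc(Cc2cnc(=O)n(CC(=O)OCC)c2)c(=O)nc1SCc1ccc(F)cc1` carries ethoxycarbonyl where compound 2 carries hydroxymethyl, and in this assay compound 1 gives 55%, so the step of a number 22 percentage points higher from compound 1 to compound 2 (beyond the scatter) is the only measured change at this position. Compound 3 `CCCCCCCCCCCCN(C)C(=O)Cn1cc(Cc2cnc(=O)n(CC(=O)N3CCNC(=O)C3)c2)c(=O)nc1SCc1ccc(F)cc1` changes the same position once more: (3-oxopiperazin-1-yl)carbonyl in place of hydroxymethyl on a saturated chain carbon bound to an aromatic nitrogen. For the measured compounds named here, no measured step covers a (3-oxopiperazin-1-yl)carbonyl group here, so the only guide is that a swap between ethoxycarbonyl and hydroxymethyl at this position gave a modest shift in the number. The expected step of a number 12 percentage points lower from compound 2 to compound 3 (beyond the scatter) is therefore small and downward, within or just beyond the scatter. In this assay compound 3 is estimated to give 65%, with a range from 40% to 88%.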

Compound 3, a percentage reported as inhibition, at one concentration (the size of the read-out at that concentration, not a potency): 86%
The estimate for compound 3 lay 21 percentage points below the measured number; the measured number falls inside the stated range.
By their numbers in this assay, from the lowest: compound 1; then compounds 2 and 3 (each within the scatter of the next).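

Going from hydroxymethyl to the much bulkier (3-oxopiperazin-1-yl)carbonyl, with 9 heavy atoms in place of 2 and a six-membered ring, gives a number 9 percentage points higher from compound 2 to compound 3 (within the scatter) in this assay, so the two groups cannot be told apart here and this position accepts the larger group without a loss. With the carbonyl kept, 3-oxopiperazin-1-yl in place of ethoxy gives a number 31 percentage points higher from compound 1 to compound 3 (beyond the scatter), which shows that the group on the carbonyl carbon decides the number, not the carbonyl alone. Nothing available explains these shifts.

Going by these compounds, it remains open whether the ring matters or simply the amide link to the carbonyl. A small dimethylamide, a plain piperazine without the ring carbonyl, or a free carboxylic acid at the same place would help to separate these possibilities.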